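Enantiomer of the cinnamate ester in the cytotoxicity series

The compounds below may be only part of what the source reports. "The series", "measured", "known", "first", "only" and "open" are said of these compounds alone.

Compound 1 `O=C1C[C@@H]2O[C@@H]([C@H](O)c3ccccc3)[C@@H](O)[C@@H]2O1` is the free alcohol of the shared core. In a functional assay on Raji cells (Homo sapiens) for cytotoxicity, read by MTT assay, with a stated time of 72 h (a higher number here means a weaker inhibitor, a lower number a stronger inhibitor), compound 1 gives only a limit, > 100000 nM, which is the limit of > 100000 nM in this assay, at which 1 of the 2 values shown sits. Going by the values given here, compound 2 `O=C(/C=C/c1ccccc1)O[C@H](c1ccccc1)[C@H]1O[C@@H]2CC(=O)O[C@@H]2[C@H]1O` carries the cinnamate ester; in this assay compound 2 gives 15500 nM, the only number among the two values shown. Compound 3 `O=C(/C=C/c1ccccc1)O[C@@H](c1ccccc1)[C@@H]1O[C@H]2CC(=O)O[C@H]2[C@@H]1O` is its mirror form: the two compounds have the same atoms and bonds and differ only in configuration as drawn: 5 of 6 stereo elements differ; a stereocentre at a saturated chain carbon is drawn R in compound 2 and S in compound 3; a stereocentre at a saturated ring carbon is drawn S in compound 2 and R in compound 3; a stereocentre at a saturated ring carbon is drawn R in compound 2 and S in compound 3; a stereocentre at a saturated ring carbon is drawn R in compound 2 and S in compound 3. Among the compounds with values here, no measured step between compounds that differ in one place is available. The expected step of a 1.9-fold higher number from compound 2 to compound 3 (0.29 log units; within the scatter) is a modest loss, possibly beyond the scatter. Compound 3 is estimated at 30000 nM, within 8000 nM to 100000 nM.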

Compound 3, half-maximal inhibitory concentration: 570 nM
Beside the measured number, compound 3's estimate is 53-fold (1.72 log units) above it; the measured number lies below the stated range.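

In this assay the configuration alone carries a large effect, with a 27-fold lower number from compound 2 to compound 3 (1.43 log units; beyond the scatter). Going by these compounds alone, the earlier compounds held a single configuration, so this is the first sign that the cinnamate ester's effect depends on the configuration as well as on the ester itself. The change can be assigned to configuration and to nothing else, because atoms and bonds stay the same: the fact that compounds 2 and 3 differ only in the configuration as drawn.

With 5 of 6 stereo elements changing together, the stereocentre that matters most remains unresolved. Also open, as far as these compounds go, is whether a benzoate ester or an amide in place of the cinnamate ester would hold up in the configuration of compound 3.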